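The compounds below may be only part of what the source reports. "The series", "measured", "known", "first", "only" and "open" are said of these compounds alone.

Measured in a physicochemical assay for solubility, in phosphate buffer, at pH 6.5; a higher number here means a more soluble compound, a lower number a less soluble compound:
- compound 1 `C=C[C@@H]1C[C@]1(NC(=O)[C@@H]1C[C@@H](Oc2nccc3cc(OC)ccc23)CN1C(=O)[C@@H](NC(=O)N[C@H](C(=O)OC)C(C)(C)C)C(C)(C)C)C(=O)NS(=O)(=O)C1CC1`: 754 ug/mL
- compound 2 `C=C[C@@H]1C[C@]1(NC(=O)[C@@H]1C[C@@H](Oc2nccc3cc(OC)ccc23)CN1C(=O)[C@@H](NC(=O)N[C@H](C(=O)OC(C)(C)C)C(C)(C)C)C(C)(C)C)C(=O)NS(=O)(=O)C1CC1`: 1 ug/mL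
- compound 3 `C=C[C@@H]1C[C@]1(NC(=O)[C@@H]1C[C@@H](Oc2nccc3cc(OC)ccc23)CN1C(=O)[C@@H](NC(=O)N[C@H](C(N)=O)C(C)(C)C)C(C)(C)C)C(=O)NS(=O)(=O)C1CC1`: 557 ug/mL

The data show a 1.4-fold lower number from compound 1 to compound 3 (0.13 log units; within the scatter) and a 560-fold higher number from compound 2 to compound 3 (2.75 log units; beyond the scatter), which puts compound 3 in the upper pair of the three numbers. Compound 4 `C=C[C@@H]1C[C@]1(NC(=O)[C@@H]1C[C@@H](Oc2nccc3cc(OC)ccc23)CN1C(=O)[C@@H](NC(=O)N[C@H](C(=O)NCc1ccccc1)C(C)(C)C)C(C)(C)C)C(=O)NS(=O)(=O)C1CC1` carries benzyl in place of hydrogen on an amide-type nitrogen. Among the compounds with values here, no measured step adds an aromatic ring. Within the data shown here, the nearest precedent is tert-butyl in place of methyl, with a 750-fold lower number from compound 1 to compound 2 (2.88 log units; beyond the scatter), a single large step. On that precedent a clear fall in this assay is expected, probably smaller than that step but uncertain in size. The expected step is a 19-fold lower number from compound 3 to compound 4 (1.27 log units; beyond the scatter). The estimate for compound 4 is 30 ug/mL, with an expected range of 2 ug/mL to 300 ug/mL.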

Compound 4, solubility: 95 ug/mL
Beside the measured number, compound 4's estimate is 3.2-fold (0.50 log units) below it; low and high end bracket the measured number.
By their numbers in this assay, from the lowest: compound 2; then compound 4; then compounds 3 and 1 (each within the scatter of the next).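

In this assay a step of a 5.9-fold lower number from compound 3 to compound 4 (0.77 log units; beyond the scatter) comes with benzyl in place of hydrogen on the amide-type nitrogen, the first read on an aromatic ring at this position. Steps of a 7.9-fold lower number from compound 1 to compound 4 (0.90 log units; beyond the scatter) and a 95-fold higher number from compound 2 to compound 4 (1.98 log units; beyond the scatter) come with benzylamino on the carbonyl carbon, so compound 4 sits between the tert-butoxy compound and the methoxy and amino compounds. No measurement on hand accounts for these differences.

Open, from the compounds shown here alone, is whether a phenyl, a longer chain carrying the ring, or an amine or carboxylic acid on the benzyl ring would change the number.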